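The source may report more compounds than this note shows. Statements on the series, on what has been measured and on what is new or still open speak of the compounds shown alone.

Measured compounds:
- Compound 1, `CCOC(=O)c1nn(-c2ccc(O)cc2)c(=O)c2c(N)scc12`: 65.8%
- Compound 2, `CCOC(=O)c1nn(-c2ccc(OC(C)=O)cc2)c(=O)c2c(N)scc12`: 48.9%

In an assay on CHO-K1 cells for displacement of a labelled ligand from adenosine receptor A1 (Homo sapiens), tested at 50 uM (a lower number here means less inhibition, a higher number more inhibition at the concentration tested (going by the name of the read-out)), compound 2 gives the lower of the two numbers shown; its nearest neighbour is compound 1, and the step of a number 16.9 percentage points lower from compound 1 to compound 2 (beyond the scatter) is beyond the scatter, though modest. Compound 3, `CCOC(=O)c1nn(-c2ccc(OS(=O)(=O)C(F)(F)F)cc2)c(=O)c2c(N)scc12`, is not yet measured. It differs from compound 2 by (trifluoromethyl)sulfonyl in place of acetyl on an oxygen on an aromatic ring. Among the measured compounds shown here, only one measured step bears on this change: from compound 1 to compound 2, where an acetyl replaced hydrogen on the same oxygen on an aromatic ring and inhibition fell by a modest amount. For the measured compounds named here, replacing the acetyl by the (trifluoromethyl)sulfonyl group has no direct precedent here, so the direction is uncertain; the prior step suggests that growing the group on this oxygen may lower inhibition a little further. Compound 3 is therefore expected to give about 40%, within 20% to 60%, a step of a number 8.9 percentage points lower from compound 2 to compound 3 (within the scatter) that is estimated to be small.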

Compound 3, a percentage reported as inhibition, at one concentration (the size of the read-out at that concentration, not a potency): 21.5%
The estimate for compound 3 lay 18.5 percentage points above the measured number; the measured number falls inside the stated range.
By their numbers in this assay, from the lowest: compound 3; then compound 2; then compound 1.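

In this assay, the change on the oxygen on an aromatic ring from acetyl to (trifluoromethyl)sulfonyl gives a number 27.4 percentage points lower from compound 2 to compound 3 (beyond the scatter) and so shows that this position still responds once it is already acylated, in the same direction as the first replacement. Among the compounds shown here, measured against the free hydroxyl, the change is a number 44.3 percentage points lower from compound 1 to compound 3 (beyond the scatter) and is the only step here graded large, so the number falls in the order hydrogen, acetyl, (trifluoromethyl)sulfonyl, with none of the three compounds going against that order. Nothing available here explains why this position responds in this way.

Open, from the compounds shown here alone, is whether a simple methyl ether or a longer acyl chain on this oxygen would fit the same order. Also open, going by these compounds, is how an amine in place of this oxygen would read in this assay on the shared core.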